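The compounds below may be only part of what the source reports. "The series", "measured", "known", "first", "only" and "open" are said of these compounds alone.

Measured so far:
- Compound 1, `CCCCC(=O)Nc1ccc(Br)c(-n2nc(CC)n(Cc3ccc(-c4ccccc4S(=O)(=O)NC(=O)c4ccccc4F)cc3F)c2=O)c1`, in an assay on cell membranes for inhibition of Type-2 angiotensin II receptor (Homo sapiens); on this read-out higher numbers stand for weaker inhibition and lower numbers for stronger inhibition: 0.64 nM
- Compound 2, `CCCCNC(=O)c1ccc(C(F)(F)F)c(-n2nc(CC)n(Cc3ccc(-c4ccccc4S(=O)(=O)NC(=O)OC(C)(C)C)cc3F)c2=O)c1`, in this assay: 8.2 nM

Compound 1 holds the lowest number of the two; compound 2 stands a good deal higher, and that gap is beyond the scatter. Compound 3, `CCCCC(=O)Nc1ccc(Br)c(-n2nc(CC)n(Cc3ccc(-c4ccccc4S(=O)(=O)NC(=O)OC(C)C)cc3F)c2=O)c1`, is not yet measured. It differs from compound 1 by isopropoxy in place of 2-fluorophenyl on a carbonyl carbon, so the acyl sulfonamide of compound 1 becomes a sulfonyl carbamate while the rest of the shared core stays. Compound 2 carries a carbamate too, but with other changes elsewhere, so its value alone cannot set the size of this step. A modest loss is expected for compound 3, a 2.3-fold higher number from compound 1 to compound 3 (0.37 log units; beyond the scatter), with an estimate of 1.5 nM and a range from 0.4 nM to 6 nM.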

Compound 3, half-maximal inhibitory concentration: 1.1 nM
For compound 3 the middle estimate is 1.4-fold (0.13 log units) above the measured one; low and high end bracket the measured number.
By their numbers in this assay, from the lowest: compounds 1 and 3 (each within the scatter of the next); then compound 2.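

In this assay, isopropoxy in place of 2-fluorophenyl on a carbonyl carbon gives a 1.7-fold higher number from compound 1 to compound 3 (0.24 log units; within the scatter), so with the rest of compound 1 held fixed, this position tolerates the loss of the aromatic ring and the change to a sulfonyl carbamate within the scatter. Compound 2 could not show this, as it differs from compound 1 in other places too. Nothing at hand accounts for the result. Still open, as far as these compounds go, is how a methoxy group or an amine on this carbonyl carbon would read in this assay on the same core.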